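The source may report more compounds than this note shows. Statements on the series, on what has been measured and on what is new or still open speak of the compounds shown alone.

Measured in a functional assay on PC-3 cells (Homo sapiens) for cytotoxicity, read by MTT assay, with a stated time of 72 h; on this read-out higher numbers stand for weaker inhibition of growth and lower numbers for stronger inhibition of growth:
compound 1, `O=C(/N=C(/NC(=O)c1cc(-c2ccccc2)nc2ccccc12)[Se]Cc1ccccc1)c1cc(-c2ccccc2)nc2ccccc12`: 97100 nM
compound 2, `O=C(/N=C(/NC(=O)c1cccs1)[Se]Cc1ccccc1)c1cccs1`: > 100000 nM, which is a limit of the assay and not a number

Among the compounds with values here, compound 1 holds the only number among the two values shown, and that number lies close to the top of the range; the other value, that of compound 2, sits at the limit of > 100000 nM in this assay, at which 1 of the 2 values shown sits. Within the data shown here, there is thus no step between measured compounds to learn from.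

Compound 3, `CS/C(=N\C(=O)c1cc(-c2ccccc2)nc2ccccc12)NC(=O)c1cc(-c2ccccc2)nc2ccccc12`, differs from compound 1 by a group of 2 heavy atoms (1 carbon, 1 sulfur; no ring) in place of a group of 8 heavy atoms (7 carbon, 1 selenium; one six-membered aromatic ring of carbon only), on a carbon with a double bond to nitrogen. Among the measured compounds shown here, with no measured step to rest on, and with compound 1 already standing at 97100 nM, compound 3 is expected to give a step of a 1.0-fold higher number from compound 1 to compound 3 (0.01 log units; within the scatter), that is, no change beyond the scatter. The estimate for compound 3 in this assay is 100000 nM, within the range 40000 nM to 250000 nM.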

Compound 3, concentration for total growth inhibition: > 100000 nM
Compound 3: only a limit was reported (the forecaster's own chance of this, stated with the estimate: 55%); the middle value lies on the limit itself.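

In this assay compound 3 gives > 100000 nM, which is a limit of the assay and not a number. On these data alone, putting methylsulfanyl on the carbon with a double bond to nitrogen, in place of the group of 8 heavy atoms that holds selenium, gives an at least 1.0-fold higher number from compound 1 to compound 3 (0.01 log units; that floor lies within the scatter), so this change brings no gain in growth inhibition that the read-out can show, and the true size of the step remains unknown. The series now sits mostly at the top of the range: the limit of > 100000 nM in this assay, at which 2 of the 3 values shown sit.

The compounds shown leave open whether any other group on this carbon, such as an amine or a longer chain like butylsulfanyl, would bring the number clear of that limit. How far compound 3 truly lies from compound 1 also stays unresolved.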